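A few compounds are considered here, and "the series" means these few. Any claim that something is new, unique, unknown or untested is made for them only; others in the source may bear on it.

The series keeps the core of compound 1 `CCn1c(C(=O)NCCNC(=O)OC(C)(C)C)ccc1C(CC)(CC)c1ccc(OCS(=O)(=O)c2ccccc2)c(C)c1` and varies only the group on the amide-type nitrogen. In a functional assay on PC-3 cells (Homo sapiens) for antiproliferative activity, read by MTT assay, with a stated time of 24 h (on this read-out lower numbers stand for stronger inhibition and higher numbers for weaker inhibition), compound 1 gives no number, only a limit, > 50000 nM. Compound 2 `CCn1c(C(=O)N[C@@H](C)CO)ccc1C(CC)(CC)c1ccc(OCS(=O)(=O)c2ccccc2)c(C)c1` carries 1-(hydroxymethyl)ethyl there, and in this assay compound 2 gives 9520 nM. Compound 3 `CCn1c(C(=O)N[C@H](CO)CCO)ccc1C(CC)(CC)c1ccc(OCS(=O)(=O)c2ccccc2)c(C)c1` carries 3-hydroxy-1-(hydroxymethyl)propyl; in this assay compound 3 gives 12100 nM, the higher of the two numbers available, though the gap to compound 2 lies within the scatter a 1.3-fold higher number from compound 2 to compound 3 (0.10 log units; within the scatter). Against the 2-((tert-butoxycarbonyl)amino)ethyl amide both hydroxyalkyl amides read lower: an at least 5.2-fold lower number from compound 1 to compound 2 (0.72 log units; beyond the scatter) and an at least 4.1-fold lower number from compound 1 to compound 3 (0.61 log units; beyond the scatter), each bounded only by the limit (the limit of > 50000 nM in this assay, at which 1 of the 3 values shown sits).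

Compound 4 `CCn1c(C(=O)NCCC(=O)O)ccc1C(CC)(CC)c1ccc(OCS(=O)(=O)c2ccccc2)c(C)c1` differs from compound 3 as follows: 2-carboxyethyl in place of 3-hydroxy-1-(hydroxymethyl)propyl on an amide-type nitrogen. Among the measured compounds shown here, no measured step involves a carboxylic acid, so the only guidance is that the two hydroxyalkyl amides sit close together while the larger carbamate-bearing chain of compound 1 reached the limit. A modest rise in this assay is expected, with a real chance of a limit again. The expected step is a 1.8-fold higher number from compound 3 to compound 4 (0.26 log units; within the scatter). Compound 4 is estimated at 22000 nM, within 7000 nM to 60000 nM.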

Compound 4, half-maximal inhibitory concentration: 14400 nM
The estimate for compound 4 lay 1.5-fold (0.18 log units) above the measured number; measured number inside the range.
By their numbers in this assay, from the lowest: compounds 2, 3 and 4 (each within the scatter of the next). At a limit, above all of these: compound 1.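

In this assay a carboxylic acid chain on the amide-type nitrogen reads level with both hydroxyalkyl chains (a 1.2-fold higher number from compound 3 to compound 4 (0.08 log units; within the scatter); a 1.5-fold higher number from compound 2 to compound 4 (0.18 log units; within the scatter)), so compounds 2, 3 and 4 give no order among themselves. Compound 4 also carries no defined stereocentre in this group, so the defined stereocentre of compound 3 is not required for a number in this range. The exchange at the far end of the chain, carboxy in place of (tert-butoxycarbonyl)amino, gives an at least 3.4-fold lower number from compound 1 to compound 4 (0.54 log units; beyond the scatter), and this step has only one bounded side, as compound 1 stands at a limit: the limit of > 50000 nM in this assay, at which 1 of the 4 values shown sits.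

From the compounds shown here alone, it remains open whether the drop from the limit follows from removing the (tert-butoxycarbonyl)amino group as such, which a free primary amine or a simple methyl ester on the same chain would help separate. Going by these compounds, it is also open whether any group on this nitrogen, such as a longer hydroxyalkyl chain or a morpholine ring, reads beyond the scatter from compound 2, which gives 9520 nM.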